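Methyl for Chloro on a Triazole Side Chain

A few compounds are considered here, and "the series" means these few. Any claim that something is new, unique, unknown or untested is made for them only; others in the source may bear on it.

Compound 1, `CCCC[C@@H](CCn1cncn1)c1ccc(Cl)cc1`: 17 ug/mL
Compound 2, `CCCC[C@@H](CCn1cncn1)c1ccc(C)cc1`: 60.7 ug/mL
Compound 3, `Clc1ccc([C@@H](CCn2cncn2)Cc2ccccc2)cc1`: 25.9 ug/mL

All three compounds were measured in an ADME assay on HEp-2 cells (Homo sapiens) for cytotoxicity, read by MTT assay, with a stated time of 3 days; on this read-out higher numbers stand for lower toxicity in this test and lower numbers for higher toxicity in this test. Compound 1 and compound 2 differ by methyl in place of chloro on an aromatic carbon, and that change gave a 3.6-fold higher number from compound 1 to compound 2 (0.55 log units; beyond the scatter). Compound 3 carries the same substituted ring as compound 1, but the difference between the two cores is not broken down here. The numbers for compound 3 and compound 1 are within the scatter of each other, while compound 2 lies beyond the scatter above compound 3.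

Compound 4, `Cc1ccc([C@@H](CCn2cncn2)Cc2ccccc2)cc1`, has not yet been measured in this assay. It differs from compound 3 by methyl in place of chloro on an aromatic carbon, which is the same change as that between compound 1 and compound 2. Because that change gave a 3.6-fold higher number from compound 1 to compound 2 (0.55 log units; beyond the scatter), a step of similar size is expected here. The expected step is a 3.1-fold higher number from compound 3 to compound 4 (0.49 log units; beyond the scatter). Compound 4 is estimated at 80 ug/mL, with an expected range from 40 ug/mL to 160 ug/mL.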

Compound 4, half-maximal cytotoxic concentration: 83.3 ug/mL
Beside the measured number, compound 4's estimate is 1.0-fold (0.02 log units) below it; the range from low to high includes it.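

In this assay, methyl in place of chloro on an aromatic carbon gave a 3.2-fold higher number from compound 3 to compound 4 (0.51 log units; beyond the scatter). Set beside the earlier pair, the change carried from the core of compound 1 to the core of compound 3 with much the same size: the same change on two cores in this assay, a 3.6-fold higher number (0.55 log units; beyond the scatter) from compound 1 to compound 2 and a 3.2-fold higher number (0.51 log units; beyond the scatter) from compound 3 to compound 4, 1.1-fold (0.05 log units) apart, within the scatter of two such steps. This shows that the step held on these two cores in this one test, but two pairs do not show that it would hold on any other core in the series, and they do not explain why the number rises with this change.

The compounds shown leave open how other groups would read at the same place on the aromatic ring, such as a methoxy group, a nitrile or a trifluoromethyl group. They also leave open whether the step would keep its size on a core carrying an amine, a carboxylic acid or a longer chain.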